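This account rests on a few compounds, and the source may have more. Where it says the series, first, only, none or still open, it means among the compounds named here.

Three compounds share one core and differ only in the group attached at one spot on that core. In an ADME assay on the whole organism (Rattus norvegicus) for pharmacokinetics, read by LC-MS, at a dose of 1 mg/kg by the intravenous route (a lower number here means that more of the compound stays in the plasma, a higher number that more of the compound sits outside the plasma), compound 1 `CNC(=O)c1c(-c2ccc(F)cc2)oc2cc(-n3nccc3-c3ccc(B(O)O)c(F)c3)c(C3CC3)cc12` gives 1.3 L/kg, compound 2 `CNC(=O)c1c(-c2ccc(F)cc2)oc2cc(N(Cc3ccc(B(O)O)c(F)c3)S(C)(=O)=O)c(C3CC3)cc12` gives 1.4 L/kg, and compound 3 `CNC(=O)c1c(-c2ccc(F)cc2)oc2cc(N3C(=O)OC[C@@H]3c3ccc(B(O)O)c(F)c3)c(C3CC3)cc12` gives 1.3 L/kg. These three numbers sit within the scatter of one another, so compound 2 cannot be told apart from compound 1 or compound 3 on this measure. Compound 4 `CNC(=O)c1c(-c2ccc(F)cc2)oc2cc(N(C3CCc4c(B(O)O)cccc43)S(C)(=O)=O)c(C3CC3)cc12` has not yet been measured in this assay. It differs from compound 2 in one place: a group of 12 heavy atoms (9 carbon, 1 boron, 2 oxygen; one five-membered non-aromatic ring of carbon only, one six-membered aromatic ring of carbon only) in place of a group of 11 heavy atoms (7 carbon, 1 boron, 2 oxygen, 1 fluorine; one six-membered aromatic ring of carbon only), on a sulfonamide nitrogen. Compound 1 with 1.3 L/kg, compound 2 with 1.4 L/kg and compound 3 with 1.3 L/kg already carry three quite different groups at this spot and still land inside the scatter, so the change to compound 4 is expected to stay inside the scatter too, with no clear direction. The step from compound 2 to compound 4 is estimated as a 1.1-fold higher number from compound 2 to compound 4 (0.03 log units; within the scatter). In this assay compound 4 is expected to give 1.5 L/kg, within a range from 0.9 L/kg to 2.6 L/kg.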

Compound 4, volume of distribution at steady state: 3.5 L/kg
Compound 4: the middle estimate sits 2.3-fold (0.37 log units) below what was measured; the whole stated range lies below it.
By their numbers in this assay, from the lowest: compounds 1, 3 and 2 (each within the scatter of the next); then compound 4.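

In this assay, the change on the sulfonamide nitrogen gives a 2.5-fold higher number from compound 2 to compound 4 (0.40 log units; beyond the scatter), so this position can shift the number beyond the scatter, which the three earlier compounds, all within the scatter of one another, did not reveal. The group that leaves and the group that enters have the same counts of hydrogen-bond donors and acceptors and no net charge, so those counts do not separate compound 2 from compound 4, while the fluorine goes and a five-membered non-aromatic ring of carbon only arrives in a single step. Nothing measured here explains the rise.

As far as these compounds go, whether the rise follows the new ring or the loss of fluorine stays open, and a group carrying both would help to separate the two. Also open, from the compounds shown here alone, is how a carboxylic acid in place of the boron would behave on this nitrogen.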